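The source may report more compounds than this note shows. Statements on the series, on what has been measured and on what is new or still open speak of the compounds shown alone.

Working notes on the series. Compound 1 `O=c1cc(CSC(=S)N2CCCCC2)oc2cc(Cl)ccc12` is the starting point. In a functional assay on HeLa cells (Homo sapiens) for antiproliferative activity, read by MTT assay, with a stated time of 72 h (a lower number here means a stronger inhibitor, a higher number a weaker inhibitor), compound 1 gives only a limit of the assay, > 25000 nM. Compound 2 `O=c1cc(CSC(=S)N2CCCC2)oc2cc(Cl)ccc12` differs from compound 1 only in carrying pyrrolidin-1-yl in place of piperidin-1-yl on the thiocarbonyl carbon. In this assay compound 2 also gives only a limit, > 40000 nM. The step that the two limits leave unreadable from compound 1 to compound 2 is therefore unreadable because the limit of > 25000 nM in this assay, at which 1 of the 2 values shown sits, and the limit of > 40000 nM in this assay, at which 1 of the 2 values shown sits, cap both ends. Among the compounds with values here, compound 2 thus stands at a limit, and the only other value is a limit as well, so no order between the two can be stated.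

Compound 3 `CC(C)N(C(=S)SCc1cc(=O)c2ccc(Cl)cc2o1)C(C)C` is the next point: diisopropylamino in place of pyrrolidin-1-yl on a thiocarbonyl carbon. Within the data shown here, the single measured step, also an amine exchange on the thiocarbonyl carbon, gives no readable size, so no measured step bears on this change with a number. With both neighbours at limits, the expectation for this step is none beyond the scatter, that is a number no higher from compound 2 to compound 3 (the limit leaves the size open) is expected. Compound 3 is therefore expected to give 40000 nM in this assay, with a range from 15000 nM to 100000 nM, and most likely only a limit again.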

Compound 3, half-maximal inhibitory concentration: > 30000 nM
Compound 3: only a limit was reported; the forecaster's own chance of this, stated with the estimate: 80%; the middle value lies beyond the limit too.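

In this assay compound 3 gives > 30000 nM, which is a limit of the assay. Within the data shown here, with compound 1, compound 2 and compound 3 all at limits, no step among them can be read. The compounds shown leave open how piperidin-1-yl, pyrrolidin-1-yl and diisopropylamino on the thiocarbonyl carbon rank, and what actual value each compound has.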